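Added ring methyl on the aryl-ether thioether series

The source may hold more compounds than are shown below. What is called first, only, known or untested is meant among the compounds shown, and "the series" means these compounds.

Of the compounds shown here, two carry numbers so far. Compound 1 `COc1ccc(Sc2ccccc2N2CC(C)N(CC(=O)O)CC2C)cc1` gives, in an assay for inhibition of sodium- and chloride-dependent glycine transporter 1 (Homo sapiens) (a lower number here means a stronger inhibitor, a higher number a weaker inhibitor), a half-maximal inhibitory concentration of 580 nM. Compound 2 `COc1ccc(Sc2ccc(OC)cc2N2CCN(CC(=O)O)C(C)C2)cc1` gives in this assay 4600 nM, the highest of the two numbers; the nearest, compound 1, sits lower by a gap beyond the usual scatter. Among the measured compounds shown here, the two differ in more than one place, so no single-change step can be drawn from their values; they show only that compound 2 is the weaker of the pair.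

Compound 3 `COc1ccc(Sc2ccc(OC)cc2N2CC(C)N(CC(=O)O)CC2C)cc1` is the next candidate. It differs from compound 2 by methyl in place of hydrogen on a saturated ring carbon, a methyl in place of hydrogen on a saturated ring carbon. This brings the saturated ring of compound 3 into the same substitution as that of compound 1, while the aryl methoxy of compound 2 is kept.

For the measured compounds named here, no measured step matches this change. A modest gain is expected from compound 2 to compound 3, a 3.1-fold lower number from compound 2 to compound 3 (0.49 log units; beyond the scatter), a step of moderate size rather than none, given that compound 1 carries the fuller ring substitution and stands at 580 nM. Compound 3 is therefore estimated at 1500 nM, within 450 nM to 5000 nM.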

Compound 3, half-maximal inhibitory concentration: > 50000 nM
Compound 3 gave a limit, no number; the forecaster's own chance of this, stated with the estimate: 3%; middle value at least 33-fold (1.52 log units) away from the limit.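

In this assay compound 3 reads > 50000 nM, which is a limit of the assay and not a number, and the steps to it carry that limit: the limit of > 50000 nM in this assay, at which 1 of the 3 values shown sits.

On this saturated ring carbon, next to the ring nitrogen, methyl in place of hydrogen is far from a neutral change in the presence of the second aryl methoxy, giving an at least 10-fold higher number from compound 2 to compound 3 (1.03 log units; beyond the scatter) and not the modest gain the earlier pair left room for. Methoxy in place of hydrogen on the aromatic carbon, with the added ring methyl present, gives an at least 86-fold higher number from compound 1 to compound 3 (1.93 log units; beyond the scatter) as the second large loss. Compound 3 is the only one of the three that carries both the added ring methyl and the second aryl methoxy, and taking away either one leaves a measurable number.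

The compounds shown leave open how far past its limit compound 3 lies and whether either change costs as much without the other. They also leave open how this ring carbon responds to an ethyl or hydroxymethyl group, and how the aromatic carbon responds to fluorine or chlorine in place of methoxy.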